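This account rests on a few compounds, and the source may have more. Where it says the series, first, only, none or still open, it means among the compounds named here.

Compound 1, `Sc1nc(NCc2ccccc2)c2ccccc2n1`: > 100000 nM in an ADME assay on BEAS-2B cells (Homo sapiens) for cytotoxicity, read by MTT assay, with a stated time of 72 h (a lower number here means a stronger inhibitor of growth, a higher number a weaker inhibitor of growth), a limit of the assay.
Compound 2, `CCCCC[Se]c1nc(NCc2ccccc2)c2ccccc2n1`: > 100000 nM in this assay, also a limit.

Neither measured compound gives a number in this assay. Compound 2 sits at the limit of > 100000 nM in this assay, at which 2 of the 2 values shown sit, so its place cannot be fixed more closely than that. The step that the two limits leave unreadable from compound 1 to compound 2 is therefore of unknown size, because both compounds rest at the limit of > 100000 nM in this assay, at which 2 of the 2 values shown sit.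

Compound 3 is `[SeH]c1nc(NCc2ccccc2)c2ccccc2n1`. It differs from compound 2 in hydrogen in place of pentyl on a selenium. Among the measured compounds shown here, no measured step bears on this change directly, and the single step that was measured cannot be sized. For the measured compounds named here, the only guidance is that both measured compounds failed to reach a readable number, so compound 3 is expected to behave alike in this assay. The step that the limit leaves unreadable from compound 2 to compound 3 is expected to show none beyond the scatter. For compound 3 the estimate is 150000 nM, with a range from 50000 nM to 500000 nM, most likely reported again as a limit.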

Compound 3, concentration for total growth inhibition: > 100000 nM
Compound 3: no number, only a limit; the forecaster's own chance of this, stated with the estimate: 80%; the middle value lies beyond the limit too.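

Among the compounds shown here, no step among compound 1, compound 2 and compound 3 can be read, because all three compounds rest at the same limit: the limit of > 100000 nM in this assay, at which 3 of the 3 values shown sit.

The compounds shown leave open whether selenium in place of sulfur, or hydrogen in place of pentyl on a selenium, changes anything in this assay.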